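Compound 3 against a series at the limit

A few compounds are considered here, and "the series" means these few. Any claim that something is new, unique, unknown or untested is made for them only; others in the source may bear on it.

Measured in a functional assay on K562 cells (Homo sapiens) for antiproliferative activity, with a stated time of 72 h; a lower number here means a stronger inhibitor, a higher number a weaker inhibitor:
- compound 1 `COc1cc(CNc2ncnc3c2ncn3[C@@H]2O[C@H](CO)[C@@H](O)[C@H]2O)cc(OC)c1`: > 166000 nM, a limit
- compound 2 `OC[C@H]1O[C@@H](n2cnc3c(NCc4cc(O)cc(O)c4)ncnc32)[C@H](O)[C@@H]1O`: > 166000 nM, a limit

Not yet measured: compound 3 `OC[C@H]1O[C@@H](n2cnc3c(NCc4ccccc4OC(F)F)ncnc32)[C@H](O)[C@@H]1O`.

Compound 2 stands at a limit and has no number of its own. Going by the values given here, the only measured step, a step that the two limits leave unreadable from compound 1 to compound 2, has no size that can be used. Among the compounds with values here, the series so far comes down to the limit of > 166000 nM in this assay, at which 2 of the 2 values shown sit. The change to compound 3 is 2-(difluoromethoxy)phenyl in place of 3,5-dihydroxyphenyl on a saturated chain carbon bound to a nitrogen on an aromatic ring, and it replaces the aryl group more fully than the measured step did. No measured step sizes such a change, so the expectation is loose: a move towards stronger inhibition, with a real chance that the result is again a limit. The expected step is an at least 3.3-fold lower number from compound 2 to compound 3 (0.52 log units; beyond the scatter) in this assay. For compound 3 the estimated value is 50000 nM, with an expected range of 8000 nM to 166000 nM.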

Compound 3, half-maximal inhibitory concentration: > 166000 nM
Compound 3: no number, only a limit; the forecaster's own chance of this, stated with the estimate: 45%; middle value at least 3.3-fold (0.52 log units) from the limit.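

In this assay no step can be read among compound 1, compound 2 and compound 3, since each gives only a limit: the limit of > 166000 nM in this assay, at which 3 of the 3 values shown sit.

The compounds shown leave open whether any aryl group on the shared core gives a measurable value, and how these three aryl groups would rank.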